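Methyl to methoxy on the pyridine-type ring of a cyclic urea

The source may hold more compounds than are shown below. What is called first, only, known or untested is meant among the compounds shown, and "the series" means these compounds.

The two measured compounds share a core bearing a methyl group on the saturated ring and an aromatic ring on a ring nitrogen. Compound 1 `CC1CN(c2cccc(F)c2)NC(=O)N1` carries a fluorine on a benzene-type ring, and in a functional assay on cells for inhibition of Polyunsaturated fatty acid 5-lipoxygenase (Homo sapiens) (on this read-out lower numbers stand for stronger inhibition and higher numbers for weaker inhibition), compound 1 gives 1800 nM. Compound 2 `Cc1cccc(N2CC(C)NC(=O)N2)n1` carries instead a six-membered aromatic ring with one nitrogen, bearing a methyl group, and in this assay compound 2 gives 1700 nM. The two numbers sit within the usual scatter of each other, so compound 2 cannot be told apart from compound 1 on this evidence.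

Compound 3 `COc1cccc(N2CC(C)NC(=O)N2)n1` is the next member. From compound 2 it differs by methoxy in place of methyl on an aromatic carbon. Among the compounds with values here, no measured pair in this small set shows what such an exchange does, so there is no basis for expecting a step beyond the scatter in either direction. The expected step from compound 2 to compound 3 is therefore no change at the digits printed from compound 2 to compound 3 (within the scatter). Compound 3 is estimated at 1700 nM in this assay, with a range from 700 nM to 4000 nM.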

Compound 3, half-maximal inhibitory concentration: 7100 nM
Compound 3: middle estimate off by 4.2-fold (0.62 log units), on the low side; the whole stated range lies below it.
By their numbers in this assay, from the lowest: compounds 2 and 1 (each within the scatter of the next); then compound 3.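

This position does not tolerate every small group equally. In this assay, within the data shown here, methoxy in place of methyl on the aromatic carbon next to the ring nitrogen gives a 4.2-fold higher number from compound 2 to compound 3 (0.62 log units; beyond the scatter), the first step in this set that lies beyond the scatter, and it goes towards weaker inhibition. The exchange is small on paper, adding one heavy atom and one hydrogen-bond acceptor, yet that is enough to separate compound 3 from compound 2, while the data offer no measurement that would explain the shift.

As far as these compounds go, with only methyl and methoxy seen at this place, it remains open whether the weaker inhibition goes with the oxygen, with the larger group or with something else, and whether an ethyl group, a chlorine atom or an amine would give a number close to that of compound 2 or close to that of compound 3. It also remains open whether the same exchange would produce a step of similar size on the fluorine-bearing ring of compound 1, where no such pair is shown.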